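Pentyl for Methoxy on the Aryl Group of Compound 1

The source may report more compounds than this note shows. Statements on the series, on what has been measured and on what is new or still open speak of the compounds shown alone.

Of the compounds shown here, three of one series have been measured in a functional assay on HCT-116 cells (Homo sapiens) for antiproliferative activity, read by MTT assay, with a stated time of 72 h; a lower number here means a stronger inhibitor, a higher number a weaker inhibitor. Among the compounds with values here, compound 1 `COc1ccc(-c2cn(C/C=C3\OC(=O)C(OCc4ccccc4)=C3OCc3ccccc3)nn2)cc1` sits at a limit of this assay, > 100000 nM, not at a number, and is the one compound of the three that rests at that limit (the limit of > 100000 nM in this assay, at which 1 of the 3 values shown sits). Compound 2 `O=C1O[C@H]([C@@H](O)Cn2cc(-c3cccc(O)c3)nn2)C(OCc2ccccc2)=C1OCc1ccccc1` gives 42900 nM in this assay. Compound 3 `O=C1O[C@H]([C@@H](O)Cn2cc(CNS(=O)(=O)c3ccc(Cl)cc3F)nn2)C(OCc2ccccc2)=C1OCc1ccccc1` gives 21600 nM in this assay. Compound 4 `CCCCCc1ccc(-c2cn(C/C=C3\OC(=O)C(OCc4ccccc4)=C3OCc3ccccc3)nn2)cc1` has not been measured yet. It differs from compound 1 in one place: pentyl in place of methoxy on an aromatic carbon. Within the data shown here, no pair of measured compounds in this set differs in a single place, so the size of such a change is unknown here; the two numbered compounds show only that the series as a whole is weak in this assay. Compound 4 is therefore expected to stay in the weak range, with an at least 1.6-fold lower number from compound 1 to compound 4 (0.22 log units; that floor lies within the scatter) meaning at most a modest gain from the limit of compound 1. The estimate for compound 4 in this assay is 60000 nM, between 15000 nM and 200000 nM.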

Compound 4, half-maximal inhibitory concentration: > 100000 nM
Compound 4: no number, only a limit; the forecaster's own chance of this, stated with the estimate: 50%; middle value at least 1.6-fold (0.22 log units) away from the limit.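

Within the data shown here, compound 4, like compound 1, rests at a limit in this assay and not at a number, so no step between them can be read: the limit of > 100000 nM in this assay, at which 2 of the 4 values shown sit.

The compounds shown leave open whether pentyl in place of methoxy changes activity at all.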